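The compounds below may be only part of what the source reports. "The series", "measured", "known", "first", "only" and "open" are said of these compounds alone.

Compound 1 `Cc1ccc(NC(=O)Nc2cccc(CNc3ncnc4ccccc34)c2)cc1` — in a functional assay on HepG2 cells (Homo sapiens) for antiproliferative activity, read by MTT assay (a lower number here means a stronger inhibitor, a higher number a weaker inhibitor), compound 1 gives > 50000 nM, which is a limit of the assay and not a number (the limit of > 50000 nM in this assay, at which 1 of the 3 values shown sits).
Compound 2 `CC(C)(C)c1ccc(NC(=O)Nc2cccc(CNc3ncnc4ccccc34)c2)cc1` — compound 2 gives 17000 nM.
Compound 3 `COc1cc2ncnc(NCc3cccc(NC(=O)Nc4ccccc4)c3)c2cc1OC` — compound 3 gives 19700 nM.

Among the measured compounds, compound 3 and compound 2 sit within the scatter of each other, so no order can be read between them. The third value is a limit only.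

Compound 4 `COc1cc2ncnc(NCc3cccc(NC(=O)Nc4cccc(C(F)(F)F)c4)c3)c2cc1OC` is not yet measured. It differs from compound 3 in one place: trifluoromethyl in place of hydrogen on an aromatic carbon. Among the measured compounds shown here, the one measured step that resembles this, a larger group placed on the same terminal ring, is an at least 2.9-fold lower number from compound 1 to compound 2 (0.46 log units; beyond the scatter); there the larger group gave the lower number. On that single precedent a modest lowering is expected here too, though one step is thin ground and a result within the scatter would not surprise.

The estimated step is a 2.5-fold lower number from compound 3 to compound 4 (0.39 log units; beyond the scatter). Compound 4 is therefore expected to give about 8000 nM, with a likely range from 3000 nM to 30000 nM.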

Compound 4, half-maximal inhibitory concentration: 34200 nM
Beside the measured number, compound 4's estimate is 4.3-fold (0.63 log units) below it; the measured number lies above the stated range.
By their numbers in this assay, from the lowest: compounds 2, 3 and 4 (each within the scatter of the next). At a limit, above all of these: compound 1.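

In this assay, placing trifluoromethyl on the outer phenyl ring of compound 3 gives a 1.7-fold higher number from compound 3 to compound 4 (0.24 log units; within the scatter), so at this position the change cannot be told apart from no change at all. The earlier evidence on this ring was tert-butyl in place of methyl, which gave an at least 2.9-fold lower number from compound 1 to compound 2 (0.46 log units; beyond the scatter), and the new step shows that such a shift does not carry over to every added group or to the core of compound 3. That earlier step also starts from compound 1, whose value is a limit and not a number: the limit of > 50000 nM in this assay, at which 1 of the 4 values shown sits.

The compounds shown leave open whether an amine or a carboxylic acid at this same place would move the number beyond the scatter. They also leave open whether tert-butyl would act on the core of compound 3 as it does on the core of compound 2.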